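Compound 1 to compound 3: oxolan-2-yl for methyl

This account rests on a few compounds, and the source may have more. Where it says the series, first, only, none or still open, it means among the compounds named here.

Going by the values given here, in a physicochemical assay for lipophilicity, at pH 7.4 (on this read-out lower numbers stand for lower lipophilicity and higher numbers for higher lipophilicity), compound 1 (`Cc1cc(C)c(CN2CCc3c(Cl)cc([C@H](C)CO)c(Cl)c3C2=O)c(=O)[nH]1`) gives 2.6, the only single number for it, as one further entry carries none. Compound 2 (`CCOC(c1cc(Cl)c2c(c1Cl)C(=O)N(Cc1c(C)cc(C)[nH]c1=O)CC2)C1CS(=O)(=O)C1`) gives 2.4; 2.3 (2 entries), and its repeat readings appear in the several entries of compound 2 in this assay, 2.4; 2.3 (2 entries). Among the compounds with values here, these values lie within the usual scatter of each other, but no measured pair differs in one place only, so no direct step is available.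

Compound 3 (`Cc1cc(C)c(CN2CCc3c(Cl)cc([C@@H](CO)[C@@H]4CCCO4)c(Cl)c3C2=O)c(=O)[nH]1`) carries oxolan-2-yl in place of methyl on a saturated chain carbon bound to an aromatic carbon and a saturated chain carbon. Compound 2, which also bears a ring on its side chain, stands at 2.4; 2.3 (2 entries), so only a small upward change in this assay is expected. The estimated size of that change is a number 0.20 log units higher from compound 1 to compound 3 (within the scatter). For compound 3 the expected value is 2.8, with an estimated range of 2.4 to 3.2.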

Compound 3, distribution coefficient: 2.1
Compound 3: middle estimate off by 0.70 log units, on the high side; the measured number lies below the stated range.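

In this assay, the saturated chain carbon bound to an aromatic carbon and a saturated chain carbon now has its first direct step: oxolan-2-yl in place of methyl gives a number 0.50 log units lower from compound 1 to compound 3 (beyond the scatter). In this pair, the larger group, with its added ring and hydrogen-bond acceptor, comes with a lower reading, so added heavy atoms at this place do not by themselves raise the number. The step rests on one number each for compound 1 and compound 3, while the repeat readings available in the series lie close together: the several entries of compound 2 in this assay, 2.4; 2.3 (2 entries)

Whether the lower reading goes with the ring oxygen or with the ring itself stays open, as an all-carbon cyclopentyl group at this place is not among the compounds shown. As far as these compounds go, how an amine or a longer chain at the same carbon would read also remains unknown.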